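Bromo for cyano on a sigma-1 ligand

This account rests on a few compounds, and the source may have more. Where it says the series, first, only, none or still open, it means among the compounds named here.

In an assay for binding affinity to Sigma non-opioid intracellular receptor 1 (Rattus norvegicus) (on this read-out higher numbers stand for weaker inhibition and lower numbers for stronger inhibition), compound 1 `Brc1ccc(OCC2CCN(CC3CC3)CC2)cc1` gives 0.6 nM, and compound 2 `N#Cc1ccc(OCC2CCN(CCCF)CC2)cc1` gives 4.3 nM. Compound 2 thus stands at the higher of the two numbers; compound 1 lies well below it, beyond the scatter of this assay, though the two compounds differ in two places, so no single step can be read from them. Compound 3 `FCCCN1CCC(COc2ccc(Br)cc2)CC1` differs from compound 2 in one place: bromo in place of cyano on an aromatic carbon, so that bromo takes the place of cyano on an aromatic carbon. For the measured compounds named here, no measured pair shows this exact exchange. Because compound 1, which also carries bromo, gives 0.6 nM in this assay, a step to a lower number is expected, of moderate size, and the expected step of a 3.3-fold lower number from compound 2 to compound 3 (0.52 log units; beyond the scatter) is estimated to lie beyond the scatter. Compound 3 is estimated at 1.3 nM in this assay, within a range from 0.4 nM to 4.5 nM.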

Compound 3, inhibition constant: 0.38 nM
For compound 3 the middle estimate is 3.4-fold (0.53 log units) above the measured one; measured number outside the range, below it.
By their numbers in this assay, from the lowest: compounds 3 and 1 (each within the scatter of the next); then compound 2.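

In this assay, for the compounds shown here, the aromatic carbon para to a large group proves sensitive to the exchange of cyano for bromo: the single change gives an 11-fold lower number from compound 2 to compound 3 (1.05 log units; beyond the scatter), the first step at this position that can be read on its own. The second exchange, 2-fluoroethyl in place of cyclopropyl on a saturated chain carbon bound to an amine nitrogen in a ring, gives a 1.6-fold lower number from compound 1 to compound 3 (0.20 log units; within the scatter), so with bromo in place these two groups cannot be told apart in this assay. Nothing measured here accounts for the size of either step.

On these data alone, how chloro or methoxy at the same aromatic carbon would compare with bromo remains open. So does whether a longer chain on the ring nitrogen would keep the number within the scatter of compound 3.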